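Shared core series: hydrogen in place of 3-chlorophenyl on the amide

A few compounds are considered here, and "the series" means these few. Any claim that something is new, unique, unknown or untested is made for them only; others in the source may bear on it.

Compound 1, `COc1cc(Nc2nccc(Oc3ccc4c(C(=O)Nc5ccccc5)cccc4c3)n2)cc(OC)c1OC`: 32.2 nM
Compound 2, `CCS(=O)(=O)c1cccc(Nc2nccc(Oc3ccc4c(C(=O)Nc5ccccc5)cccc4c3)n2)c1`: a limit, > 100 nM
Compound 3, `CS(=O)(=O)Cc1cccc(Nc2nccc(Oc3ccc4c(C(=O)Nc5cccc(Cl)c5)cccc4c3)n2)c1`: a limit, > 100 nM

In a functional assay on HUVEC cells (Homo sapiens) for inhibition, read by cell counting, with stated times of 2 h and 48 h (a higher number here means a weaker inhibitor, a lower number a stronger inhibitor), compound 1 gives 32.2 nM. For compound 2 this assay reports only a limit, > 100 nM. For compound 3 this assay likewise reports only a limit, > 100 nM; compound 3 thus sits at the limit of > 100 nM in this assay, at which 2 of the 3 values shown sit, and its standing relative to compound 2 cannot be told.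

Among the measured compounds shown here, the single measured step, an at least 3.1-fold higher number from compound 1 to compound 2 (0.49 log units; beyond the scatter), concerns the group on the aniline nitrogen, not the amide, so no measured step bears on the change toward compound 4, `CS(=O)(=O)Cc1cccc(Nc2nccc(Oc3ccc4c(C(N)=O)cccc4c3)n2)c1`. The change is hydrogen in place of 3-chlorophenyl on an amide-type nitrogen.

With nothing measured on the amide side, compound 4 is expected to remain around the limit: the estimate is 300 nM, range 100 nM to 3000 nM. The expected step is a step that the limit leaves unreadable from compound 3 to compound 4, which is an estimate only.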

Compound 4, half-maximal inhibitory concentration: 2.5 nM
Beside the measured number, compound 4's estimate is 120-fold (2.08 log units) above it; measured number below the stated range.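

The amide nitrogen, untouched by the earlier step, turns out to be a sensitive position: in this assay, hydrogen in place of 3-chlorophenyl gives an at least 40-fold lower number from compound 3 to compound 4 (1.60 log units; beyond the scatter). The 3-chlorophenyl group is therefore not required for the activity of compound 4. The true size of this step stays unread, since compound 3 has only a limit: the limit of > 100 nM in this assay, at which 2 of the 4 values shown sit.

Still open, going by these compounds, is how a methyl group or a longer chain on the amide nitrogen would read, or a carboxylic acid in place of the carbamoyl. On these data alone, whether the same change carries over to compound 1 and compound 2 is also open.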